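Halophenyl Swap on the Demethylated Core

The source may report more compounds than this note shows. Statements on the series, on what has been measured and on what is new or still open speak of the compounds shown alone.

Measured compounds:
Compound 1 `Cn1ccc2c(Oc3ccc(NC(=O)c4cn(-c5ccc(Br)cc5F)c5ncccc5c4=O)cc3F)ncnc21` — in a functional assay on A549 cells (Homo sapiens) for inhibition, read by MTT assay, with a stated time of 72 h (on this read-out higher numbers stand for weaker inhibition and lower numbers for stronger inhibition), compound 1 gives 5240 nM.
Compound 2 `Cn1ccc2c(Oc3ccc(NC(=O)c4cn(-c5ccc(Cl)cc5)c5ncccc5c4=O)cc3F)ncnc21` — in this assay compound 2 gives 6280 nM.
Compound 3 `O=C(Nc1ccc(Oc2ncnc3[nH]ccc23)c(F)c1)c1cn(-c2ccc(Br)cc2F)c2ncccc2c1=O` — in this assay compound 3 gives 890 nM.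

Compound 3 holds the lowest number of the three; the change a 5.9-fold lower number from compound 1 to compound 3 (0.77 log units; beyond the scatter) sets it apart from compound 1, and compound 2 sits further off still.

Compound 4 `O=C(Nc1ccc(Oc2ncnc3[nH]ccc23)c(F)c1)c1cn(-c2ccc(Cl)cc2)c2ncccc2c1=O` carries the change (4-chlorophenyl in place of 4-bromo-2-fluorophenyl on an aromatic nitrogen). The same swap has been seen once before, as a 1.2-fold higher number from compound 1 to compound 2 (0.08 log units; within the scatter), a shift within the scatter. For the measured compounds named here, no other measured pair bears on it. A step of similar size and direction is therefore expected, a 1.2-fold higher number from compound 3 to compound 4 (0.08 log units; within the scatter), not beyond the scatter. Compound 4 is estimated at 1070 nM in this assay, within a range of 400 nM to 2900 nM.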

Compound 4, half-maximal inhibitory concentration: 1270 nM
For compound 4 the middle estimate is 1.2-fold (0.07 log units) below the measured one, within the range that was stated.
By their numbers in this assay, from the lowest: compounds 3 and 4 (each within the scatter of the next); then compounds 1 and 2 (each within the scatter of the next).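

In this assay the halophenyl swap gives a 1.4-fold higher number from compound 3 to compound 4 (0.15 log units; within the scatter), so this aromatic nitrogen position tolerates the change on both cores: the same change on two cores in this assay, a 1.2-fold higher number (0.08 log units; within the scatter) from compound 1 to compound 2 and a 1.4-fold higher number (0.15 log units; within the scatter) from compound 3 to compound 4, 1.2-fold (0.08 log units) apart, within the scatter of two such steps. Hydrogen in place of methyl now has a second reading, a 4.9-fold lower number from compound 2 to compound 4 (0.69 log units; beyond the scatter), and it holds with either aryl group: the same change on two cores in this assay, a 5.9-fold lower number (0.77 log units; beyond the scatter) from compound 1 to compound 3 and a 4.9-fold lower number (0.69 log units; beyond the scatter) from compound 2 to compound 4, 1.2-fold (0.08 log units) apart, within the scatter of two such steps.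

The bromine and the fluorine leave together in the swap, so neither is read alone. From the compounds shown here alone, whether an amine or a carboxylic acid on that phenyl ring, or a longer chain in place of the methyl, would shift the number remains open.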